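A few compounds are considered here, and "the series" means these few. Any claim that something is new, unique, unknown or untested is made for them only; others in the source may bear on it.

Of the compounds shown here, three have so far been measured in an ADME assay on microsomes from liver (Mus musculus) for metabolic stability; on this read-out lower numbers stand for slow clearance and higher numbers for fast clearance. Compound 1 `COc1cc([C@](O)(CCN(C)C)[C@@H](c2cc3cc(Br)ccc3nc2OC)c2ccnc(OC)c2OC)cc(OC(F)F)n1` gives 4.9 uL/min in this assay. Compound 2 `COc1cc([C@](O)(CCN(C)C)[C@@H](c2cc3cc(C#N)ccc3nc2OC)c2ccnc(OC)c2OC)cc(OC(F)F)n1` differs from compound 1 by cyano in place of bromo on an aromatic carbon. In this assay compound 2 gives 11 uL/min; the change made a 2.2-fold higher number from compound 1 to compound 2 (0.35 log units; beyond the scatter). Compound 3 `COc1cc([C@](O)(CCN(C)C)[C@@H](c2cc3cc(Br)ccc3nc2OC)c2cccc(OC)c2F)cc(SC)n1` rests on a different core, and the difference between the core of compound 1 and the core of compound 3 is not broken down here. In this assay compound 3 gives 20 uL/min, the highest of the three numbers; its gap to compound 2 lies within the usual scatter, while its gap to compound 1 lies beyond it.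

Compound 4 `COc1cc([C@](O)(CCN(C)C)[C@@H](c2cc3cc(C#N)ccc3nc2OC)c2cccc(OC)c2F)cc(SC)n1` has not yet been measured. It differs from compound 3 by cyano in place of bromo on an aromatic carbon, the same change that separates compound 2 from compound 1, made at the same place, so that among the compounds shown this change occurs twice in all. Among the measured compounds shown here, since its one measured instance gave a 2.2-fold higher number from compound 1 to compound 2 (0.35 log units; beyond the scatter), the step from compound 3 to compound 4 is expected to be a 2.0-fold higher number from compound 3 to compound 4 (0.30 log units; within the scatter), set a little short of the earlier one because compound 3 already gives 20 uL/min and only one prior example of the change is available. Compound 4 is therefore expected to give 40 uL/min in this assay, with the estimate spanning 20 uL/min to 80 uL/min.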

Compound 4, intrinsic clearance in a liver preparation (reported as CLH), per the amount of preparation that the assay uses: 36 uL/min
Beside the measured number, compound 4's estimate is 1.1-fold (0.05 log units) above it, within the range that was stated.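

In this assay, replacing bromo with cyano on the core of compound 3 gives a 1.8-fold higher number from compound 3 to compound 4 (0.26 log units; within the scatter), so this step alone cannot be told apart from the variation between repeated measurements. Set beside the earlier instance of the same change, the step carries over from one core to the other with no difference in size that the data can resolve: the same change on two cores in this assay, a 2.2-fold higher number (0.35 log units; beyond the scatter) from compound 1 to compound 2 and a 1.8-fold higher number (0.26 log units; within the scatter) from compound 3 to compound 4, 1.2-fold (0.10 log units) apart, within the scatter of two such steps This agreement rests on only two matched pairs, one of which lies within the scatter when taken alone, so it does not establish a rule for other cores in the series, and it does not show what sets the size of the step.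

The compounds shown leave open which of the several differences between the core of compound 1 and the core of compound 3 accounts for the gap between their numbers, since no pair separates those differences one at a time. They also leave open how this read-out would respond to a chloro group, a methyl group or an amine on the same aromatic carbon, as only bromo and cyano appear there.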